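Moving the Hydroxyl: What to Expect for Compound 4

This account rests on a few compounds, and the source may have more. Where it says the series, first, only, none or still open, it means among the compounds named here.

All three measured compounds were tested in a functional assay on HCT-15 cells (Homo sapiens) for cytotoxicity, read by CCK-8 assay; a lower number here means a stronger inhibitor, a higher number a weaker inhibitor.

compound 1 `Oc1ccc(-c2cc(-c3ccoc3)cc(-c3cccc(O)c3)n2)cc1`: 930 nM
compound 2 `Oc1cccc(-c2cc(-c3cccnc3)cc(-c3ccccc3O)n2)c1`: 8280 nM
compound 3 `Oc1cccc(-c2cc(-c3cccnc3)cc(-c3cccc(O)c3)n2)c1`: > 50000 nM, a limit of the assay

Compound 3 stands at the edge of what this assay reports: for compound 3 only the limit of > 50000 nM in this assay, at which 1 of the 3 values shown sits, is known, with no number behind it. The one measured step among these compounds, an at least 6.0-fold higher number from compound 2 to compound 3 (0.78 log units; beyond the scatter), is beyond the scatter and ends at that limit.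

Compound 4 `Oc1ccc(-c2cc(-c3cccnc3)cc(-c3cccc(O)c3)n2)cc1` differs from compound 3 by 4-hydroxyphenyl in place of 3-hydroxyphenyl on an aromatic carbon. For the measured compounds named here, no measured step covers this particular change; the step of an at least 6.0-fold higher number from compound 2 to compound 3 (0.78 log units; beyond the scatter) concerns a different move of the hydroxyl and bears on it only indirectly, showing that shifting the hydroxyl on this core can move the number a great deal. Compound 1, which also carries a 4-hydroxyphenyl group, gives a number well within the measurable range, but it differs from compound 4 in one further place, so it can only hint at the direction.

Against that background compound 4 is expected to give a lower number than the limit, an estimated step of an at least 3.3-fold lower number from compound 3 to compound 4 (0.52 log units; beyond the scatter). Compound 4 is estimated at 15000 nM, within a range of 2000 nM to 60000 nM, with a real chance that only a limit is reported again.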

Compound 4, half-maximal inhibitory concentration: > 50000 nM
Compound 4: only a limit was reported; the forecaster's own chance of this, stated with the estimate: 35%; middle value at least 3.3-fold (0.52 log units) from the limit.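

In this assay, compound 4 gives only a limit, as compound 3 does, so the change from 3-hydroxyphenyl to 4-hydroxyphenyl at this position next to the ring nitrogen cannot be read, and neither group can be ranked over the other: the limit of > 50000 nM in this assay, at which 2 of the 4 values shown sit.

With 4-hydroxyphenyl in place of 2-hydroxyphenyl at the same position, the result is an at least 6.0-fold higher number from compound 2 to compound 4 (0.78 log units; beyond the scatter), so among the pyridin-3-yl compounds shown, only the one carrying 2-hydroxyphenyl gives a number rather than a limit. The change at the other place, pyridin-3-yl in place of furan-3-yl, gives an at least 53-fold higher number from compound 1 to compound 4 (1.73 log units; beyond the scatter), which shows that the 4-hydroxyphenyl and 3-hydroxyphenyl pair does not bring the limit by itself, since with furan-3-yl the same pair gives a number.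

From the compounds shown here alone, how far beyond the limit compound 3 and compound 4 truly lie stays open. Also open, going by these compounds, is whether a methoxy group in place of the hydroxyl, or an amine on this phenyl ring, would bring a pyridin-3-yl compound back into the measurable range, and what 2-hydroxyphenyl would give alongside furan-3-yl.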